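A few compounds are considered here, and "the series" means these few. Any claim that something is new, unique, unknown or untested is made for them only; others in the source may bear on it.

Measured so far in an assay on isolated protein for inhibition of Monoamine oxidase (Rattus norvegicus); on this read-out higher numbers stand for weaker inhibition and lower numbers for stronger inhibition:
compound 1 `C=C=CCN(C)Cc1ccccc1`: 8200 nM
compound 2 `C=C=C(CN)Cc1ccccc1`: 20000 nM
compound 3 `C=C=C(CN)Cc1ccc(Cl)cc1`: 260 nM

Compound 3 gives the lowest number of the three, beyond the scatter from both others; the nearest is compound 1, the furthest compound 2. Compound 4 `C=C=C(CN)Cc1ccc(C)cc1` differs from compound 3 in one place: methyl in place of chloro on an aromatic carbon. Going by the values given here, one measured step bears on this position, a 77-fold lower number from compound 2 to compound 3 (1.89 log units; beyond the scatter), where chloro replaced hydrogen. Among the compounds with values here, no measured step compares methyl with chloro, so the size of the move for methyl is not given by the series. Compound 4 is expected to land between the hydrogen and chloro analogues, a moderate rise in the number, a 5.8-fold higher number from compound 3 to compound 4 (0.76 log units; beyond the scatter). For compound 4 the estimate in this assay is 1500 nM, with a range from 400 nM to 6000 nM.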

Compound 4, half-maximal inhibitory concentration: 1100 nM
Compound 4: the middle estimate sits 1.4-fold (0.13 log units) above what was measured; the measured number falls inside the stated range.
By their numbers in this assay, from the lowest: compound 3; then compound 4; then compound 1; then compound 2.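

In this assay, the gain at this aromatic carbon is not confined to chloro: methyl in place of hydrogen also gives a large drop (an 18-fold lower number from compound 2 to compound 4 (1.26 log units; beyond the scatter)). Chloro nevertheless keeps a modest edge over methyl (a 4.2-fold higher number from compound 3 to compound 4 (0.63 log units; beyond the scatter)), so the two groups of one heavy atom each are not interchangeable here. Nothing measured accounts for the gap between them.

Open, as far as these compounds go, is where bromo, methoxy or trifluoromethyl in this place would fall relative to chloro and methyl. Also open, from the compounds shown here alone, is whether either group gives a similar step on the core of compound 1.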